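Amino in place of hydrogen on the shared core

The compounds below may be only part of what the source reports. "The series", "measured", "known", "first", "only" and "open" are said of these compounds alone.

Measured so far:
compound 1 `Cc1noc(NS(=O)(=O)c2cccc3ccccc23)c1C` — 3100 nM
compound 2 `Cc1noc(NS(=O)(=O)c2cccc3c(NC(C)C)cccc23)c1C` — 5 nM

In an assay on thoracic aorta for binding affinity to Endothelin-1 receptor (Rattus norvegicus) (on this read-out higher numbers stand for weaker inhibition and lower numbers for stronger inhibition), compound 1 gives 3100 nM, the highest of the two numbers. The nearest is compound 2, which gives 5 nM. Among the compounds with values here, the one step between measured compounds is a 620-fold lower number from compound 1 to compound 2 (2.79 log units; beyond the scatter), which lies beyond the scatter; compound 2 carries an isopropylamino group where compound 1 carries hydrogen.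

Compound 3 `Cc1noc(NS(=O)(=O)c2cccc3cc(N)ccc23)c1C` differs from compound 1 by amino in place of hydrogen on an aromatic carbon. The entering group sits on an aromatic carbon of a six-membered aromatic ring of carbon only, part of a fused or bridged system of two rings, meta to a fused ring and para to a fused ring. Within the data shown here, the only step that bears on this change is the one from compound 1 to compound 2, but the entering group there is isopropylamino and its place on the core is not the same as here, so it is a loose guide only. A lowering of the number is expected, smaller than the step to compound 2. Compound 3 is expected to give 600 nM in this assay, within 100 nM to 3000 nM. The expected step is therefore a 5.2-fold lower number from compound 1 to compound 3 (0.71 log units; beyond the scatter).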

Compound 3, half-maximal inhibitory concentration: 2400 nM
The estimate for compound 3 lay 4.0-fold (0.60 log units) below the measured number; measured number inside the range.
By their numbers in this assay, from the lowest: compound 2; then compounds 3 and 1 (each within the scatter of the next).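

In this assay, amino on this aromatic carbon, meta to a fused ring and para to a fused ring, gives no readable change (a 1.3-fold lower number from compound 1 to compound 3 (0.11 log units; within the scatter)), so hydrogen and amino cannot be told apart at this place on the shared core. The large step seen earlier (a 620-fold lower number from compound 1 to compound 2 (2.79 log units; beyond the scatter)) therefore does not extend to every nitrogen-linked group at every place on the core: that step brings isopropylamino to a different place, whereas amino at this place leaves the number within the scatter of compound 1. No supporting measurement bears on why the amino group at this place has so little effect on the number.

The compounds shown do not separate the contribution of the group from that of its place, since isopropylamino and amino differ in both, and neither group appears at the other's place. Amino at the place held by isopropylamino in compound 2, isopropylamino at the place held by amino in compound 3, and a methylamino or dimethylamino group at either place would each address part of that question.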